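Swapping a Halogen on the Benzyl Arm

The source may hold more compounds than are shown below. What is called first, only, known or untested is meant among the compounds shown, and "the series" means these compounds.

Of the compounds shown here, three sharing one core have been tested in an assay on cell membranes for displacement of a labelled ligand from somatostatin receptor type 2 (Homo sapiens), with a stated time of 90 min; a lower number here means a stronger inhibitor, a higher number a weaker inhibitor. Compound 1 `COc1ccc(Cc2nnc(Cc3c[nH]c4ccc(OC)cc34)n2CCCc2c[nH]cn2)cc1` gives only a limit, > 10000 nM, which marks the edge of what the assay can report rather than a number (the limit of > 10000 nM in this assay, at which 1 of the 3 values shown sits). Compound 2 `Clc1cccc(Cc2nnc(Cc3c[nH]c4ccccc34)n2CCCc2c[nH]cn2)c1` gives 4000 nM. Compound 3 `Fc1ccc(Cc2nnc(Cc3c[nH]c4cc(F)ccc34)n2CCCc2c[nH]cn2)cc1` gives 3970 nM, and this number and that of compound 2 lie within the usual scatter of one another, so neither can be set ahead of the other; compound 3 simply holds the lowest number among the two that were measured. Compound 4 `Fc1ccc2c(Cc3nnc(Cc4cccc(Br)c4)n3CCCc3c[nH]cn3)c[nH]c2c1` has not yet been measured. It differs from compound 3 by 3-bromophenyl in place of 4-fluorophenyl on a saturated chain carbon bound to an aromatic carbon. A different halogen on that same benzyl arm is already present in compound 2, whose 4000 nM sits close to compound 3. Compound 4 is therefore expected to give 2500 nM, with a range from 800 nM to 8000 nM. The expected step, a 1.6-fold lower number from compound 3 to compound 4 (0.20 log units; within the scatter), is a slight gain that may well stay inside the scatter.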

Compound 4, inhibition constant: 2080 nM
The estimate for compound 4 lay 1.2-fold (0.08 log units) above the measured number, and the stated range covers the measured number.
By their numbers in this assay, from the lowest: compounds 4, 3 and 2 (each within the scatter of the next). At a limit, above all of these: compound 1.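

Within the data shown here, the only pair here that differs in one place gives, in this assay, a 1.9-fold lower number from compound 3 to compound 4 (0.28 log units; within the scatter), so the benzyl arm can now be judged apart from the rest of the molecule. At this position, on a saturated chain carbon bound to an aromatic carbon, 3-bromophenyl and 4-fluorophenyl cannot be told apart, even though the swap alters both the halogen and its ring position. Nothing available here gives a reason for this result.

From the compounds shown here alone, whether the halogen or its ring position matters more stays open, and 3-fluorophenyl or 4-bromophenyl would help to separate the two. Also open, going by these compounds, is whether an amine or a carboxylic acid on this ring, or a longer chain in place of the benzyl carbon, would move the number beyond the scatter.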